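Chain-end exchange on the propyl arm: amino to methoxycarbonyl

This account rests on a few compounds, and the source may have more. Where it says the series, first, only, none or still open, it means among the compounds named here.

Measured so far in a functional assay on the whole organism (strain Wistar albino) for inhibition, with Rattus norvegicus as the target, read by paw edema, with stated times of 30 min and 3 h, at a dose of 10 mg/kg by the oral route; on this read-out lower numbers stand for less inhibition and higher numbers for more inhibition at the one dose given (going by the name of the read-out):
compound 1 `COc1ccc(F)cc1-c1cccc(-c2nn(CCCC#N)c(=O)o2)c1` gives 85%
compound 2 `COc1ccc(F)cc1-c1cccc(-c2n[nH]c(=O)o2)c1` gives 71%
compound 3 `COc1ccc(F)cc1-c1cccc(-c2nn(CCCN)c(=O)o2)c1` gives 77%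

Compound 3 stands second highest of the three numbers. Its nearest neighbour is compound 2, a number 6 percentage points higher from compound 2 to compound 3 (within the scatter), and its furthest is compound 1, a number 8 percentage points lower from compound 1 to compound 3 (within the scatter), both within the scatter. Compound 4 `COC(=O)CCCn1nc(-c2cccc(-c3cc(F)ccc3OC)c2)oc1=O` differs from compound 3 by methoxycarbonyl in place of amino on a saturated chain carbon, three bonds along the chain from an aromatic nitrogen. For the measured compounds named here, the only measured step at that chain terminus is the one to compound 3 from compound 1, a number 8 percentage points lower from compound 1 to compound 3 (within the scatter), which stayed within the scatter; the steps of a number 14 percentage points lower from compound 1 to compound 2 (beyond the scatter) and a number 6 percentage points higher from compound 2 to compound 3 (within the scatter) concern hydrogen on the aromatic nitrogen and bear less directly. No step beyond the scatter is therefore expected in this assay for compound 4 in either direction. Compound 4 is estimated at 79% in this assay, with a range of 68% to 89%. The expected step of a number 2 percentage points higher from compound 3 to compound 4 (within the scatter) is thus small.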

Compound 4, a percentage reported as inhibition, in the whole organism at one dose (the size of the read-out at that dose, not a potency): 87%
For compound 4 the middle estimate is 8 percentage points below the measured one; low and high end bracket the measured number.
By their numbers in this assay, from the lowest: compounds 2, 3, 1 and 4 (each within the scatter of the next, the first and the last beyond it).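

In this assay, the chain end of the propyl arm accepts all three groups shown: methoxycarbonyl in place of amino gives a number 10 percentage points higher from compound 3 to compound 4 (within the scatter), and methoxycarbonyl in place of cyano gives a number 2 percentage points higher from compound 1 to compound 4 (within the scatter). Against hydrogen on the aromatic nitrogen, the 3-(methoxycarbonyl)propyl arm gives a number 16 percentage points higher from compound 2 to compound 4 (beyond the scatter), so it joins the nitrile-ended arm, whereas the 3-aminopropyl arm stays within the scatter of compound 2. No evidence on the cause accompanies these numbers. Going by these compounds, whether a carboxylic acid at the chain end, or a longer chain carrying methoxycarbonyl, would stay level with compound 4 remains open.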